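The compounds below may be only part of what the source reports. "The series", "measured", "known", "first", "only" and "open" are said of these compounds alone.

Working notes on the series in a functional assay on CCRF-CEM cells (Homo sapiens) for cytotoxicity, in the absence of a further agent; a higher number here means a weaker inhibitor, a lower number a stronger inhibitor. Compound 1 (`COC(=O)c1ccc(CN(CCCc2c(N)nc(N)nc2O)c2cc(F)cc(F)c2[N+](=O)[O-])cc1`) gives > 100000 nM, which is a limit of the assay and not a number. Compound 2 (`Nc1nc(N)c(CCCNc2cc(F)ccc2[N+](=O)[O-])c(O)n1`) gives > 100000 nM, which is likewise a limit. Compound 1 therefore stands on (the limit of > 100000 nM in this assay, at which 2 of the 3 values shown sit), and no exact position can be given for it. For the measured compounds named here, compound 3 (`CC(C)(C)OC(=O)CCC(Nc1ccc(CN(CCCc2c(N)nc(N)nc2O)c2cc(F)c([N+](=O)[O-])cc2[N+](=O)[O-])cc1)C(=O)OC(C)(C)C`) gives 2600 nM, the only true number so far. It differs from compound 1 in more than one place, so no single structural change can be read from that value.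

Compound 4 (`COC(=O)c1ccc(CN(CCCc2c(N)nc(N)nc2O)c2cc(F)c(F)cc2[N+](=O)[O-])cc1`) keeps the rest of compound 1 and has 4,5-difluoro-2-nitrophenyl in place of 3,5-difluoro-2-nitrophenyl on an amine nitrogen. Going by the values given here, no step between measured compounds is available to size this change. The expected step in this assay is none beyond the scatter, with no direction favoured. That expectation rests on compound 1, whose > 100000 nM is a limit. The estimated step, an at least 1.2-fold lower number from compound 1 to compound 4 (0.09 log units; that floor lies within the scatter), is therefore only a rough expectation, and a reported limit is as likely as a number. For compound 4 the expected value is 80000 nM, with an estimated range of 20000 nM to 200000 nM.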

Compound 4, half-maximal inhibitory concentration: 55000 nM
Compound 4: the middle estimate sits 1.5-fold (0.16 log units) above what was measured; low and high end bracket the measured number.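

In this assay, for the compounds shown here, the exchange of 3,5-difluoro-2-nitrophenyl for 4,5-difluoro-2-nitrophenyl on an amine nitrogen, with the same atoms joined differently, gives the first step that can be read: an at least 1.8-fold lower number from compound 1 to compound 4 (0.25 log units; that floor lies within the scatter). Compound 1 gives > 100000 nM, which is a limit of the assay and not a number. The step is therefore only a floor, and its true size remains unknown, because it starts from a limit: the limit of > 100000 nM in this assay, at which 2 of the 4 values shown sit.

On these data alone, whether this change has an effect beyond the scatter stays open, since a floor within the scatter neither shows nor excludes one. Also open, as far as these compounds go, is how compound 4, which gives 55000 nM, would respond if its methyl ester were replaced by a carboxylic acid, its chain by a longer chain, or one fluorine of the 4,5-difluoro-2-nitrophenyl group by an amine.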